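This account rests on a few compounds, and the source may have more. Where it says the series, first, only, none or still open, it means among the compounds named here.

Measured so far:

Compound 1, `O=C(CN1CCN(c2cccc(F)c2)CC1)Nc1nc2c(s1)CCCC2` — in an assay on isolated protein for inhibition of long-chain fatty acid transport protein 1 (Mus musculus), read by scintillation counting, with a stated time of 20 min (on this read-out higher numbers stand for weaker inhibition and lower numbers for stronger inhibition), compound 1 gives > 10000 nM, which is a limit of this assay rather than a number.

Compound 2, `O=C(CN1CCN(c2ccncc2)CC1)Nc1nc2c(s1)CCCC2` — in this assay compound 2 gives > 10000 nM, again a limit of the assay and not a number.

The two compounds share one core and differ only in the aromatic group on the ring amine nitrogen. The step between them, a step that the two limits leave unreadable from compound 1 to compound 2, cannot be read in size or direction, since both values sit at the same limit, as summarised in the limit of > 10000 nM in this assay, at which 2 of the 2 values shown sit. Compound 2 therefore stands only as a limit: it shows no measurable inhibition up to the edge of what this assay reports.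

Compound 3, `Cc1ccc(N2CCN(CC(=O)Nc3nc4c(s3)CCCC4)CC2)cc1`, is not yet measured. It differs from compound 2 by 4-methylphenyl in place of pyridin-4-yl on an amine nitrogen in a ring. Within the data shown here, the only measured step that touches this position, from compound 1 to compound 2, is unreadable, so it gives no guide to direction or size beyond the scatter. The expectation for compound 3 in this assay rests on the two limits alone: the step that the limit leaves unreadable from compound 2 to compound 3 is expected to be small, and compound 3 is estimated at 15000 nM, with a range from 4000 nM to 60000 nM, most likely reported again only as a limit.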

Compound 3, half-maximal inhibitory concentration: > 10000 nM
Compound 3 ended at the assay's limit; the forecaster's own chance of this, stated with the estimate: 75%; the middle value lies beyond the limit too.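

The steps among compound 1, compound 2 and compound 3 cannot be read in size or direction, as all three values are the same limit and not numbers: the limit of > 10000 nM in this assay, at which 3 of the 3 values shown sit.

The compounds shown leave open how strongly any of the three inhibits in this assay, and whether any other group on this ring amine nitrogen would give a readable number.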